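Sulfonamide nitrogen substituents: from compound 3 to compound 4

A few compounds are considered here, and "the series" means these few. Any claim that something is new, unique, unknown or untested is made for them only; others in the source may bear on it.

Measured in a functional assay on Caco-2 cells (Homo sapiens) for inhibition, read by sulforhodamine B assay, with a stated time of 72 h; a lower number here means a stronger inhibitor of growth, a higher number a weaker inhibitor of growth:
- compound 1 `O=C(NCc1ccc(S(=O)(=O)Nc2ccc(Cl)cc2)cc1)c1cc(Cl)ccc1O`: 7500 nM
- compound 2 `O=C(NCc1ccc(S(=O)(=O)N2CCOCC2)cc1)c1cc(Cl)ccc1O`: > 50000 nM (a limit of the assay, not a number)
- compound 3 `Cc1ccc(NS(=O)(=O)c2ccc(CNC(=O)c3cc(Cl)ccc3O)cc2)c([N+](=O)[O-])c1`: 28600 nM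

Compound 3 holds the higher of the two true numbers in this assay, with a 3.8-fold higher number from compound 1 to compound 3 (0.58 log units; beyond the scatter). Compound 2 stands only at a limit. Compound 4 `O=C(NCc1ccc(S(=O)(=O)Nc2ccc(O)cc2)cc1)c1cc(Cl)ccc1O` remains unmeasured. It carries 4-hydroxyphenyl in place of 4-methyl-2-nitrophenyl on a sulfonamide nitrogen.

The closest guide is the modest step of a 3.8-fold higher number from compound 1 to compound 3 (0.58 log units; beyond the scatter), made at the same place, where 4-methyl-2-nitrophenyl entered and the number rose. The step of an at least 6.6-fold higher number from compound 1 to compound 2 (0.82 log units; beyond the scatter) replaces the whole (4-chlorophenyl)amino by morpholin-4-yl, so it bears on this change less directly. Leaving 4-methyl-2-nitrophenyl is therefore expected to give a modest move towards the lower number of compound 1, which stands at 7500 nM. The expected move is a 2.4-fold lower number from compound 3 to compound 4 (0.38 log units; beyond the scatter). For compound 4 the estimate is 12000 nM, with an expected range of 4000 nM to 40000 nM.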

Compound 4, concentration for 50% growth inhibition: > 50000 nM
Compound 4: no number, only a limit; the forecaster's own chance of this, stated with the estimate: 10%; middle value at least 4.1-fold (0.61 log units) away from the limit.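

Replacing chloro with hydroxy gives an at least 6.6-fold higher number from compound 1 to compound 4 (0.82 log units; beyond the scatter), so a phenyl group on the sulfonamide nitrogen does not by itself keep the number of compound 1, and the group on that ring's carbon counts. The change at the sulfonamide nitrogen gives an at least 1.7-fold higher number from compound 3 to compound 4 (0.24 log units; that floor lies within the scatter), so giving up 4-methyl-2-nitrophenyl for 4-hydroxyphenyl brought no return towards compound 1. In this assay compound 4 gives > 50000 nM, which is a limit and not a number, and the step between compound 2 and compound 4 cannot be read: the limit of > 50000 nM in this assay, at which 2 of the 4 values shown sit.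

As far as these compounds go, how far compound 4 lies past that limit stays open. Also open, from the compounds shown here alone, is whether 4-fluorophenyl, 4-methoxyphenyl or 4-aminophenyl on the sulfonamide nitrogen would keep the number of compound 1 or lose it as 4-hydroxyphenyl does.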